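The compounds below may be only part of what the source reports. "The series", "measured", "known", "first", "only" and "open" are said of these compounds alone.

Compound 1 `Cc1ccc(N2C(=O)C=CC2OCC(F)(F)F)cc1` gives 7140 nM in a functional assay on K562 cells (Homo sapiens) for inhibition (on this read-out lower numbers stand for stronger inhibition and higher numbers for weaker inhibition), and compound 2 `O=C1C=CC(OCC(F)(F)F)N1c1ccc(F)c(Cl)c1` gives 6320 nM, a gap that stays within the usual scatter. Compound 3 `O=C1C=CC(OCC(F)(F)F)N1c1ccc(C(F)(F)F)cc1` carries trifluoromethyl in place of methyl on an aromatic carbon. Among the measured compounds shown here, no pair of measured compounds differing in one place is available to size this kind of step. Since compound 1 at 7140 nM and compound 2 at 6320 nM sit within the scatter despite different groups on that ring, only a small step is expected, a 1.2-fold lower number from compound 1 to compound 3 (0.08 log units; within the scatter), in no sure direction. Compound 3 is therefore estimated at 6000 nM in this assay, between 2500 nM and 15000 nM.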

Compound 3, half-maximal inhibitory concentration: 13100 nM
Compound 3: the middle estimate sits 2.2-fold (0.34 log units) below what was measured; measured number inside the range.
By their numbers in this assay, from the lowest: compounds 2, 1 and 3 (each within the scatter of the next, the first and the last beyond it).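

In this assay, trifluoromethyl in place of methyl on an aromatic carbon, para to a large group, gives a 1.8-fold higher number from compound 1 to compound 3 (0.26 log units; within the scatter), the first step sized at this position. Going from one heavy atom to four there thus leaves a difference that stays within the scatter, so no effect of this change can be read. No supporting evidence bears on this result. On these data alone, it remains open whether a different kind of group on this carbon, such as an amine or a carboxylic acid, would shift the number beyond the scatter.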